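Hydroxy in Place of Nitro in a Cytotoxicity Series

A few compounds are considered here, and "the series" means these few. Any claim that something is new, unique, unknown or untested is made for them only; others in the source may bear on it.

Compound 1 `O=C(CSc1nnc(-c2ccncc2)o1)N/N=C/c1ccc([N+](=O)[O-])cc1` carries a 4-nitrophenyl group on a carbon with a double bond to nitrogen. In a functional assay on SW 1116 cells (Homo sapiens) for cytotoxicity, read by MTT assay, with a stated time of 48 h (on this read-out higher numbers stand for weaker inhibition and lower numbers for stronger inhibition), compound 1 gives 25800 nM. Compound 2 `O=C(CSc1nnc(-c2ccncc2)o1)N/N=C/c1ccc(O)cc1` differs from it by hydroxy in place of nitro on an aromatic carbon, and in this assay compound 2 gives 12200 nM; the step is a 2.1-fold lower number from compound 1 to compound 2 (0.33 log units; beyond the scatter). Compound 3 `O=C(CSc1nnc(-c2ccncc2)o1)N/N=C/c1ccccc1[N+](=O)[O-]` differs from compound 1 by 2-nitrophenyl in place of 4-nitrophenyl on a carbon with a double bond to nitrogen; in this assay compound 3 gives 30700 nM, a step of a 1.2-fold higher number from compound 1 to compound 3 (0.08 log units; within the scatter), while from compound 2 the step is a 2.5-fold higher number from compound 2 to compound 3 (0.40 log units; beyond the scatter). Compound 4 `O=C(CSc1nnc(-c2ccncc2)o1)N/N=C/c1ccccc1O`, not yet measured, differs from compound 3 by hydroxy in place of nitro on an aromatic carbon. This is the same kind of change as that from compound 1 to compound 2, though the place is not identical: there the group sits para to a large group, here ortho to a large group. Because the step of a 2.1-fold lower number from compound 1 to compound 2 (0.33 log units; beyond the scatter) was modest, a step of similar size is expected from compound 3 to compound 4, namely a 2.0-fold lower number from compound 3 to compound 4 (0.31 log units; beyond the scatter). Compound 4 is therefore estimated at 15000 nM, with a likely range from 6000 nM to 40000 nM.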

Compound 4, half-maximal inhibitory concentration: 7380 nM
The estimate for compound 4 lay 2.0-fold (0.31 log units) above the measured number; the measured number falls inside the stated range.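

Hydroxy in place of nitro goes with a lower number in this assay in both pairs, with a 4.2-fold lower number from compound 3 to compound 4 (0.62 log units; beyond the scatter) as the new example, and the two examples do not differ by more than the scatter allows: the same change on two cores in this assay, a 2.1-fold lower number (0.33 log units; beyond the scatter) from compound 1 to compound 2 and a 4.2-fold lower number (0.62 log units; beyond the scatter) from compound 3 to compound 4, 2.0-fold (0.29 log units) apart, within the scatter of two such steps. Within these compounds the change therefore carried over from one core to the other in direction and, as far as the data can tell, in size; the two hydroxy compounds cannot be told apart, at a 1.7-fold lower number from compound 2 to compound 4 (0.22 log units; within the scatter), whereas 2-hydroxyphenyl in place of 4-nitrophenyl gives a 3.5-fold lower number from compound 1 to compound 4 (0.54 log units; beyond the scatter). Two pairs in a single cell assay do not show why the number falls, nor that the change would behave the same way on a core with a different structure.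

The compounds shown leave open whether an amine or a carboxylic acid in place of nitro would give a step like that of hydroxy. They also leave open whether the step would survive a longer chain in the linker of the shared core.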